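A few compounds are considered here, and "the series" means these few. Any claim that something is new, unique, unknown or untested is made for them only; others in the source may bear on it.

Measured compounds:
compound 1, `CC1=C(C(=O)OCc2ccccn2)C(c2cccc(O)c2)C2=C(CCCC2=O)N1` — 1.58
compound 2, `CC1=C(C(=O)OCc2cccnc2)C(c2ccccc2)C2=C(CCCC2=O)N1` — 2.35

Both compounds were examined in a physicochemical assay for lipophilicity, measured as octanol-water partition; a higher number here means a more lipophilic compound, a lower number a more polar compound. Compound 1 gives 1.58, the lower of the two numbers; compound 2 gives 2.35, a value that lies beyond the usual scatter above compound 1. The two compounds differ in more than one place, so no single change can be read from that gap.

Compound 3, `COc1ccc(C2C(C(=O)OCc3ccccn3)=C(C)NC3=C2C(=O)CCC3)cc1`, has not yet been measured in this assay. It differs from compound 1 in one place: 4-methoxyphenyl in place of 3-hydroxyphenyl on a saturated ring carbon. With this change the single hydrogen-bond donor of the group that leaves is gone, while one hydrogen-bond acceptor remains.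

Within the data shown here, no measured pair shows this exact change, so the expectation rests on what the two measured values show. Since compound 2, which also carries no hydroxyl group on its phenyl ring, gives 2.35, the step from compound 1 to compound 3 is expected to be upward and beyond the scatter, about a number 0.72 log units higher from compound 1 to compound 3 (beyond the scatter). Compound 3 is therefore estimated at 2.3, within a range from 1.9 to 2.7.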

Compound 3, partition coefficient: 1.9
Estimate against measurement, compound 3: 0.40 log units above; the range from low to high includes it.
By their numbers in this assay, from the lowest: compound 1; then compound 3; then compound 2.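

At this saturated ring carbon, putting 4-methoxyphenyl in place of 3-hydroxyphenyl gives a number 0.32 log units higher from compound 1 to compound 3 (beyond the scatter) in this assay. Among these compounds, this is the first single change that can be read here. The change bundles several differences, since the hydrogen-bond donor of the group that leaves is gone, the hydroxyl becomes a methoxy, and the substituent's number in the group's name moves from 3 to 4, so this one step cannot divide its size among them. Nothing available explains the shift, and it stands here as an observation only.

Steps involving compound 2 cannot be read, as it differs from compound 1 and compound 3 in more than one place. Open, then, is how much of the shift belongs to capping the hydroxyl and how much to where the substituent sits, which a 3-methoxyphenyl or a 4-hydroxyphenyl group on the same carbon would help separate, and how a quite different group there, such as an aminophenyl, would behave.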